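Removing the para fluorine from the phenoxy group

This account rests on a few compounds, and the source may have more. Where it says the series, first, only, none or still open, it means among the compounds named here.

The measured set in an assay on cells for inhibition of Voltage-dependent T-type calcium channel subunit alpha-1H (Homo sapiens), read by FLIPR and calcium flux, with stated times of 600 s and 300 s (on this read-out higher numbers stand for weaker inhibition and lower numbers for stronger inhibition), is small:
Compound 1, `NCCCOc1ccc(CNc2nc3ccc(Oc4cccc(C(F)(F)F)c4)cc3s2)cc1`, gives 171000 nM.
Compound 2, `NCCCOc1ccc(CNc2nc3ccc(Oc4ccc(O)cc4)cc3s2)cc1`, gives 300000 nM.
Compound 3, `NCCCOc1ccc(CNc2nc3ccc(Oc4ccc(F)cc4)cc3s2)cc1`, gives 688000 nM.

Compound 3 stands at the highest number of the three, separated from compound 2 by a 2.3-fold higher number from compound 2 to compound 3 (0.36 log units; beyond the scatter) and from compound 1 by a 4.0-fold higher number from compound 1 to compound 3 (0.60 log units; beyond the scatter), while the comparison between the other two, a 1.8-fold higher number from compound 1 to compound 2 (0.24 log units; within the scatter), stays within the scatter.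

Compound 4, `NCCCOc1ccc(CNc2nc3ccc(Oc4ccccc4)cc3s2)cc1`, is not yet measured. It differs from compound 3 by hydrogen in place of fluoro on an aromatic carbon.

For the measured compounds named here, no measured step shows exactly this change. The nearest is the step from compound 2 to compound 3, in which the hydroxy was replaced by fluoro at the same place and the number rose by a 2.3-fold higher number from compound 2 to compound 3 (0.36 log units; beyond the scatter), a modest shift. Taking that as the only guide, and noting that compound 1 and compound 2 carry other groups at this position and lie lower, the expectation for compound 4 is a number near that of compound 3 or somewhat lower, with the step likely small, estimated as a 1.4-fold lower number from compound 3 to compound 4 (0.14 log units; within the scatter).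

Compound 4 is therefore expected to show about 500000 nM in this assay, in a range from 200000 nM to 1500000 nM.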

Compound 4, half-maximal inhibitory concentration: > 1000000 nM
Compound 4: only a limit was reported; the forecaster's own chance of this, stated with the estimate: 25%; at least 2.0-fold (0.30 log units) between middle value and limit.
By their numbers in this assay, from the lowest: compounds 1 and 2 (each within the scatter of the next); then compound 3. At a limit, above all of these: compound 4.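

The value of compound 4 in this assay is a limit and not a number: the limit of > 1000000 nM in this assay, at which 1 of the 4 values shown sits. Taking away the fluoro, on the aromatic carbon para to a large group, gives an at least 1.4-fold higher number from compound 3 to compound 4 (0.16 log units; that floor lies within the scatter), so the floor of this step does not by itself separate hydrogen from fluoro at this place. For the compounds shown here, the other two steps do separate: hydrogen in place of hydroxy gives an at least 3.3-fold higher number from compound 2 to compound 4 (0.52 log units; beyond the scatter), and hydrogen in place of trifluoromethyl gives an at least 5.8-fold higher number from compound 1 to compound 4 (0.76 log units; beyond the scatter), which sets the phenyl of compound 4 clearly apart from the rings of these two compounds in a way the earlier comparisons could not.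

As far as these compounds go, the true size of the step between the fluoro and hydrogen compounds stays open, and with it whether the fluoro makes any difference in this assay. Also open, from the compounds shown here alone, is whether a methoxy group, an amine or a carboxylic acid on this ring would give a lower number than the hydroxy or trifluoromethyl groups, and whether a longer chain in place of the aminopropoxy chain would shift the numbers.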